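An Ester in Place of the Acid Chain

This account rests on a few compounds, and the source may have more. Where it says the series, first, only, none or still open, it means among the compounds named here.

Measured in a functional assay on the whole organism for inhibition, with Rattus norvegicus as the target, read by paw edema, with stated times of 1 h and 3 h; on this read-out higher numbers stand for an effect only at larger amounts of compound and lower numbers for an effect already at smaller amounts:
Compound 1 `C/C(=N\OCCCC(=O)O)c1ccc(Cl)cc1`: 58 mg/kg
Compound 2 `C/C(=N\OCCCCCC(=O)O)c1ccc(Cl)cc1`: 92 mg/kg

For the measured compounds named here, compound 1 has only one measured neighbour, and the two values lie within the scatter of each other, so neither compound can be ranked above the other. The next compound to be tested is compound 3 `C/C(=N\OCC(=O)OC(C)C)c1ccc(Cl)cc1`. It carries isopropoxycarbonyl in place of 2-carboxyethyl on a saturated chain carbon bound to an oxygen.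

Going by the values given here, only one measured step bears on this change, and it is a 1.6-fold higher number from compound 1 to compound 2 (0.20 log units; within the scatter). That step altered the same chain and produced no shift that can be told from the scatter. Among the compounds with values here, it offers only indirect guidance, however, since no measured compound carries isopropoxycarbonyl. The data therefore give no reason to expect a shift in either direction, though they leave the range wide.

The expected step is a 1.2-fold higher number from compound 1 to compound 3 (0.08 log units; within the scatter), which would be no change beyond the scatter. For compound 3 the estimated value is 70 mg/kg, with an expected range of 30 mg/kg to 160 mg/kg.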

Compound 3, dose for half-maximal effect: 50 mg/kg
The estimate for compound 3 lay 1.4-fold (0.15 log units) above the measured number; the measured number falls inside the stated range.
By their numbers in this assay, from the lowest: compounds 3, 1 and 2 (each within the scatter of the next).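

In this assay, isopropoxycarbonyl in place of 2-carboxyethyl on a saturated chain carbon bound to an oxygen gives a 1.2-fold lower number from compound 1 to compound 3 (0.06 log units; within the scatter). Compounds 1 and 2 both end in a carboxylic acid and differ only in the chain that carries it, so they could not show what happens when that acid is absent. Compound 3 shows that, at this place, an ester with 0 hydrogen-bond donors, against 1 in the group it replaces, gives a number that cannot be told apart from that of compound 1, although nothing available explains this outcome.

Because this single change replaces the acid with an ester and also alters the chain, the compounds shown cannot separate the contribution of the isopropyl ester from that of the shorter link to the oxygen, and carboxymethyl at the same place would be the direct comparison for compound 3. On these data alone, it also remains open whether a methyl ester, a primary amide or an amine at this place would give a number within the scatter of these three compounds or one clearly apart from them.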